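Hydrazone Swap on a Weakly Inhibiting Acrylamide Series

This account rests on a few compounds, and the source may have more. Where it says the series, first, only, none or still open, it means among the compounds named here.

Compound 2 `CN(C)C/C=C/C(=O)Nc1cccc(Nc2nc(N/N=C/c3ccncc3)ncc2Cl)c1` is the weaker of the two measured compounds: in an ADME assay on HT-29 cells (Homo sapiens) for inhibition, read by MTT assay, with a stated time of 72 h (on this read-out higher numbers stand for weaker inhibition and lower numbers for stronger inhibition), compound 2 gives 25200 nM, the highest of the two numbers in hand. The nearest neighbour, compound 1 `C=CC(=O)Nc1cccc(Nc2nc(N/N=C/c3ccc(F)cc3F)ncc2Cl)c1`, gives 4760 nM in this assay, a gap that lies beyond the usual scatter. Compound 3 `C/C(=N\Nc1ncc(Cl)c(Nc2cccc(NC(=O)/C=C/CN(C)C)c2)n1)c1ccccn1` has not yet been measured. It differs from compound 2 by a group of 9 heavy atoms (7 carbon, 2 nitrogen; one six-membered aromatic ring with 1 hetero atom) in place of a group of 8 heavy atoms (6 carbon, 2 nitrogen; one six-membered aromatic ring with 1 hetero atom), on a nitrogen on an aromatic ring. Among the compounds with values here, no pair of measured compounds shares this change, so the data give no size for such a step. On that basis the step of a 1.4-fold lower number from compound 2 to compound 3 (0.15 log units; within the scatter) is expected to be small, most likely within the usual scatter of repeated measurements, with no clear direction. The estimate for compound 3 is therefore 18000 nM, with an expected range from 5000 nM to 60000 nM in this assay.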

Compound 3, half-maximal inhibitory concentration: 120 nM
Beside the measured number, compound 3's estimate is 150-fold (2.18 log units) above it; measured number below the stated range.
By their numbers in this assay, from the lowest: compound 3; then compound 1; then compound 2.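

In this assay, replacing the group of 8 heavy atoms with the group of 9 heavy atoms, on a nitrogen on an aromatic ring, gives a 210-fold lower number from compound 2 to compound 3 (2.32 log units; beyond the scatter). This shows that the position is highly sensitive to a change that looks slight by the counts: both groups hold one six-membered aromatic ring with 1 hetero atom and 1 double bond outside aromatic rings, and they differ by 7 carbon against 6 carbon. Nothing available explains the size of this step.

The compounds shown leave open whether the same change would carry over to the side chain of compound 1. They also leave open whether the step would survive with a phenyl ring in place of the ring in the entering group, or with an ethyl group added to its chain.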